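Aryl change on the shared core: compound 1 to compound 3

A few compounds are considered here, and "the series" means these few. Any claim that something is new, unique, unknown or untested is made for them only; others in the source may bear on it.

Measured so far:
compound 1, `COc1cncc(-c2c(C)nn(-c3nc(-c4ccc(Cl)c(Cl)c4)c(SC(C)C)s3)c2C(=O)O)c1`: 21000 nM
compound 2, `Cc1oncc1-c1nc(-n2nc(C(=O)O)c(-c3cc(Cl)cc(Cl)c3)c2C)sc1SC(C)C`: > 44000 nM

Among the measured compounds shown here, in a functional assay on BJAB cells (Homo sapiens) for antiproliferative activity, with a stated time of 4 days (a lower number here means that less compound is needed, a higher number that more compound is needed for the effect), compound 1 gives 21000 nM, the only number in the set. For compound 2 only a limit of the assay is recorded, (the limit of > 44000 nM in this assay, at which 1 of the 2 values shown sits), not a number.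

Compound 3, `COc1cc(Cl)cc(-c2c(C)nn(-c3nc(-c4ccc(Cl)c(Cl)c4)c(SC(C)C)s3)c2C(=O)O)c1`, is not yet measured. It differs from compound 1 by 3-chloro-5-methoxyphenyl in place of 5-methoxypyridin-3-yl on an aromatic carbon. For the measured compounds named here, no step between measured compounds is available for this change, so the expected step in this assay is small, in either direction or none beyond the scatter. Compound 3 is expected to give 15000 nM, between 5000 nM and 45000 nM. The expected step from compound 1 is a 1.4-fold lower number from compound 1 to compound 3 (0.15 log units; within the scatter).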

Compound 3, half-maximal effective concentration: 760 nM
Beside the measured number, compound 3's estimate is 20-fold (1.30 log units) above it, and the stated range ends above it.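

In this assay, the aryl group on this aromatic carbon of the shared core has a large effect on the read-out: 3-chloro-5-methoxyphenyl in place of 5-methoxypyridin-3-yl gives a 28-fold lower number from compound 1 to compound 3 (1.44 log units; beyond the scatter). Among the compounds shown here, this is the first comparison that changes a single place, and it favours the carbon-only ring bearing chlorine. Nothing shown accounts for the size of this step. The compounds shown leave open how the step divides between loss of the ring nitrogen and gain of the chlorine. Going by these compounds, what a nitrile or an amine in place of that chlorine would give also stays open.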